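The compounds below may be only part of what the source reports. "The series", "measured", "known", "first", "only" and "open" are said of these compounds alone.

Compounds measured so far:
compound 1 `COc1ccc(S(=O)(=O)N2CCc3cccc(-c4ccc([N+](=O)[O-])cc4)c32)cc1` gives 53.1 nM in a functional assay on NCI-H460 cells (Homo sapiens) for inhibition, with a stated time of 72 h; a higher number here means a weaker inhibitor, a lower number a stronger inhibitor;
compound 2 `COc1ccc(S(=O)(=O)N2CCc3cccc(-c4ccc(O)cc4)c32)cc1` gives 114 nM in this assay.

Compound 1 stands at the lowest of the two numbers in this assay, with compound 2 the nearest at a 2.1-fold higher number from compound 1 to compound 2 (0.33 log units; beyond the scatter). Compound 3 `COc1ccc(S(=O)(=O)N2CCc3cccc(-c4ccc(N(C)C)cc4)c32)cc1` differs from compound 1 by dimethylamino in place of nitro on an aromatic carbon. For the measured compounds named here, only one step bears on it: the change from nitro to hydroxy on this aromatic carbon gave a 2.1-fold higher number from compound 1 to compound 2 (0.33 log units; beyond the scatter). Another group in place of nitro at the same carbon is therefore expected to raise the number modestly, as a 1.9-fold higher number from compound 1 to compound 3 (0.27 log units; within the scatter). Compound 3 is expected to give 100 nM, with a likely range from 40 nM to 250 nM.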

Compound 3, half-maximal inhibitory concentration: 556 nM
The estimate for compound 3 lay 5.6-fold (0.75 log units) below the measured number; the whole stated range lies below it.
By their numbers in this assay, from the lowest: compound 1; then compound 2; then compound 3.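

In this assay, dimethylamino in place of nitro gives a 10-fold higher number from compound 1 to compound 3 (1.02 log units; beyond the scatter) and so is a large step, which shows that this carbon, para to a large group, tolerates replacement of nitro far less uniformly than the hydroxy compound alone suggested. Dimethylamino in place of hydroxy gives a 4.9-fold higher number from compound 2 to compound 3 (0.69 log units; beyond the scatter) as well, so the two replacements of nitro do not fall together. Nothing available here explains this order.

From the compounds shown here alone, whether a primary amine, a carboxylic acid or a methoxy group on this carbon would stand nearer compound 1 or nearer compound 3 remains open.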